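The compounds below may be only part of what the source reports. "The series", "measured", "known", "first", "only" and "open" are said of these compounds alone.

Measured so far in a functional assay on CCRF-CEM cells (Homo sapiens) for inhibition; on this read-out lower numbers stand for stronger inhibition and higher numbers for weaker inhibition:
- compound 1 `C#CCN(Cc1ccc2nc(C)nc(O)c2c1)c1ccc([N+](=O)[O-])c(C(F)(F)F)c1`: 10500 nM
- compound 2 `C#CCN(Cc1ccc2nc(C)nc(O)c2c1)c1ccc(S(=O)(=O)N2CCOCC2)cc1`: 4500 nM

Compound 2 holds the lower of the two numbers at 4500 nM, which makes it the stronger inhibitor of the pair. Compound 1 stands higher at 10500 nM, and this gap lies beyond the usual scatter of repeated measurements. Among the measured compounds shown here, with only two values available, the series offers no trend to extend.

The next compound is compound 3 `C#CCN(Cc1ccc2nc(C)nc(O)c2c1)c1ccc(S(=O)(=O)N2CCNCC2)cc1`, which keeps the shared core and the sulfonyl link of compound 2. The change is piperazin-1-yl in place of morpholin-4-yl on a sulfonyl sulfur. For the measured compounds named here, no measured pair shows this exchange or any other single change, so the data give no direct guide to its size or direction. The starting point is therefore compound 2 at 4500 nM, and the default expectation is no shift beyond the scatter. The estimated step, a 1.1-fold lower number from compound 2 to compound 3 (0.05 log units; within the scatter), is expected to stay within the scatter of this assay, with either direction open. For compound 3 the expected value is 4000 nM, with an estimated range of 1500 nM to 12000 nM.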

Compound 3, half-maximal inhibitory concentration: 48000 nM
For compound 3 the middle estimate is 12-fold (1.08 log units) below the measured one, outside the stated range (above it).
By their numbers in this assay, from the lowest: compound 2; then compound 1; then compound 3.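

Among the compounds shown here, this is the first single-place exchange. In this assay piperazin-1-yl in place of morpholin-4-yl on a sulfonyl sulfur gives an 11-fold higher number from compound 2 to compound 3 (1.03 log units; beyond the scatter) and so marks this position as sensitive to the exchange, even though both groups count the same heavy atoms and form a six-membered non-aromatic ring with the same number of hetero atoms. The counted differences are a ring nitrogen in place of the ring oxygen and one added hydrogen-bond donor, but no available measurement links either difference to the higher number, which remains an observation on this one pair.

The compounds shown do not separate the effect of the ring nitrogen from that of its hydrogen, a question that piperidin-1-yl or an acetyl group on the piperazine nitrogen would address in the same setting. From the compounds shown here alone, it also remains open whether the same exchange gives a step of similar size and direction on other compounds, or whether this result is confined to the pair compared here.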